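The source may hold more compounds than are shown below. What is called first, only, known or untested is meant among the compounds shown, and "the series" means these compounds.

Going by the values given here, compound 3 `Nc1nc(O)c2c(n1)n(C1OC(CO)[C@@H](O)[C@H]1O)c(=O)n2Cc1ccc(Cl)c(Cl)c1` gives 0% in a functional assay on the whole organism with Mus musculus as the target (a lower number here means a smaller maximal response, a higher number a larger maximal response), the lowest of the three numbers measured so far; compound 1 `C=CCn1c(=S)n([C@@H]2O[C@H](CO)[C@H]3OC(C)(C)O[C@H]32)c2nc(N)nc(O)c21` gives 9%, which lies within the scatter of compound 3, and compound 2 `COc1ccc(Cn2c(=O)n(C3OC(CO)[C@@H](O)[C@H]3O)c3nc(N)nc(O)c32)cc1` gives 14%. Compound 4 `Cn1c(=O)n(C2OC(CO)[C@@H](O)[C@H]2O)c2nc(N)nc(O)c21` differs from compound 3 by hydrogen in place of 3,4-dichlorophenyl on a saturated chain carbon bound to an aromatic nitrogen. Among the compounds with values here, the only measured step at the same place is the one with a number 14 percentage points lower from compound 2 to compound 3 (beyond the scatter), a modest drop; no measured step removes the aromatic ring altogether. Within the data shown here, since every number so far is small, no shift beyond the scatter is expected in this assay in either direction, with at most a slight upward lean. Compound 4 is therefore expected to give 8%, in a range from 0% to 22%, meaning an expected step of a number 8 percentage points higher from compound 3 to compound 4 (within the scatter).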

Compound 4, largest response reached (reported as maximal response), in percent of the reference or control that the assay uses: 100%
Beside the measured number, compound 4's estimate is 92 percentage points below it; the measured number lies above the stated range.
By their numbers in this assay, from the lowest: compounds 3, 1 and 2 (each within the scatter of the next, the first and the last beyond it); then compound 4.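

On a saturated chain carbon bound to an aromatic nitrogen, exchanging one substituted phenyl for another changed the number only modestly, whereas removing the aromatic ring altogether gives a number 100 percentage points higher from compound 3 to compound 4 (beyond the scatter) and a number 86 percentage points higher from compound 2 to compound 4 (beyond the scatter). The ring itself therefore matters far more in this assay than the substituents tried on it, at least for compound 2, compound 3 and compound 4. No measured evidence here explains this jump.

Going by these compounds, whether the response falls gradually or abruptly as the group grows remains open. An ethyl group, a longer chain or an unsubstituted benzyl at this place could help to settle that.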